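Estimating growth inhibition for a 2,4-dichlorophenyl swap

This account rests on a few compounds, and the source may have more. Where it says the series, first, only, none or still open, it means among the compounds named here.

- compound 1 `O=C(Cc1csc2nc(-c3ccc(Br)cc3)cn12)N/N=C/c1ccc(O)cc1` gives 43700 nM
- compound 2 `COc1cccc(OC)c1/C=N/NC(=O)Cc1csc2nc(-c3ccc(Br)cc3)cn12` gives 49000 nM

In a functional assay on SN12C cells (Homo sapiens) for inhibition, read by sulforhodamine B assay, with a stated time of 48 h (a lower number here means a stronger inhibitor of growth, a higher number a weaker inhibitor of growth), compound 2 lies within the scatter of compound 1, so the two cannot be ranked. The next compound, compound 3 `O=C(Cc1csc2nc(-c3ccc(Br)cc3)cn12)N/N=C/c1ccc(Cl)cc1Cl`, has not been measured. It differs from compound 2 as follows: 2,4-dichlorophenyl in place of 2,6-dimethoxyphenyl on a carbon with a double bond to nitrogen. Going by the values given here, the only measured change at this place, a 1.1-fold higher number from compound 1 to compound 2 (0.05 log units; within the scatter), was small, so no clear step is expected in this assay. Among the compounds with values here, no measured compound carries the 2,4-dichlorophenyl group, which leaves the range wide. The estimated step is a 1.2-fold lower number from compound 2 to compound 3 (0.09 log units; within the scatter), which is no expected change beyond the scatter. The expected value for compound 3 is 40000 nM, with an estimated range from 15000 nM to 90000 nM as its limits.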

Compound 3, concentration for total growth inhibition: > 100000 nM
Compound 3 was reported as a limit; the forecaster's own chance of this, stated with the estimate: 20%; middle value at least 2.5-fold (0.39 log units) from the limit.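

Compound 3 is reported only as a limit in this assay: the limit of > 100000 nM in this assay, at which 1 of the 3 values shown sits. Measured against the 4-hydroxyphenyl group, the 2,4-dichlorophenyl group gives an at least 2.2-fold higher number from compound 1 to compound 3 (0.35 log units; beyond the scatter), so the group on this carbon can change the reading, which the earlier pair did not show. Measured against the 2,6-dimethoxyphenyl group, the same change gives an at least 2.0-fold higher number from compound 2 to compound 3 (0.30 log units; that floor lies within the scatter), so that floor alone does not separate these two groups.

The compounds shown leave open whether one chlorine on the phenyl ring would be enough for this change. They also leave open how an aminophenyl or carboxyphenyl group would read at this place.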